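The source may hold more compounds than are shown below. What is called first, only, known or untested is meant among the compounds shown, and "the series" means these compounds.

Measured compounds:
- compound 1, `Cc1cc(Nc2nccc(Nc3ccc4nc[nH]c4c3)n2)ccc1N1CCN(C)CC1`: 1.8 mL.min-1.g-1
- compound 2, `Cc1cccc(Nc2ncc([N+](=O)[O-])c(Nc3ccc4nc[nH]c4c3)n2)c1`: 19 mL.min-1.g-1

In an ADME assay on microsomes from liver (Homo sapiens) for metabolic stability, read by HPLC, using NADPH, with a stated time of 30 min, tested at 0.5 uM (a lower number here means slower removal, a higher number faster removal of the compound), compound 1 gives 1.8 mL.min-1.g-1, the lower of the two numbers recorded. The other measured compound, compound 2, gives 19 mL.min-1.g-1 in this assay, a difference that lies beyond the usual scatter; the two compounds differ in several places at once, so their values are simply reported side by side and no single change is read from them.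

The step considered here leads from compound 1 to compound 3, `CN1CCN(c2ccc(Nc3nccc(Nc4ccc5nc[nH]c5c4)n3)cc2)CC1`, which has not yet been tested in this assay. The change is hydrogen in place of methyl on an aromatic carbon. Among the compounds with values here, with no measured pair showing this change, the expectation rests on the standing of compound 1 alone: the step from compound 1 to compound 3 is expected to be small, a 1.2-fold lower number from compound 1 to compound 3 (0.08 log units; within the scatter), and within the scatter. Compound 3 is therefore estimated at 1.5 mL.min-1.g-1, with a range from 0.7 mL.min-1.g-1 to 3.5 mL.min-1.g-1.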

Compound 3, intrinsic clearance in microsomes in the Homo sapiens assay: 0.8 mL.min-1.g-1
Compound 3: the middle estimate sits 1.9-fold (0.27 log units) above what was measured; the range from low to high includes it.
By their numbers in the Homo sapiens assay, from the lowest: compound 3; then compound 1; then compound 2.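

Compounds 1 and 2 differed in several places at once, so they could not show what this position contributes on its own. Removing the methyl from the aromatic carbon ortho to the 4-methylpiperazin-1-yl group is a single change, and in the Homo sapiens assay it gives a 2.3-fold lower number from compound 1 to compound 3 (0.35 log units; beyond the scatter). In a physicochemical assay for solubility, read by HPLC, in phosphate buffer, at pH 7.4 (a higher number here means a more soluble compound, a lower number a less soluble compound), compound 1 gives 16000 nM and compound 3 gives 124000 nM, so the same change also goes with a rise in solubility: the measured solubility of compound 1, 16000 nM, and of compound 3, 124000 nM, a 7.8-fold higher number (0.89 log units; beyond the scatter)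

A single pair cannot tell whether the two shifts are linked, or whether the lower number in the Homo sapiens assay would hold on another core. Nor do these compounds show how a fluorine, a chlorine or a methoxy group on the same carbon would compare with hydrogen and methyl.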